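This account rests on a few compounds, and the source may have more. Where it says the series, first, only, none or still open, it means among the compounds named here.

Measured in a functional assay on A-431 cells (Homo sapiens) for cytotoxicity, read by MTT assay, with a stated time of 24 h; on this read-out lower numbers stand for stronger inhibition and higher numbers for weaker inhibition:
compound 1 `COc1ccccc1-n1cc(COc2c(/C=C\C(=O)O)ccc(OC)c2CC=C(C)C)nn1`: 32600 nM
compound 2 `COc1ccc(/C=C\C(=O)O)c(OCc2cn(-c3ccccc3)nn2)c1CC=C(C)C`: 21200 nM
compound 3 `COc1ccc(/C=C\C(=O)O)c(OCc2cn(-c3ccccc3I)nn2)c1CC=C(C)C`: 32700 nM

Compound 3 sits within the scatter of both others: a 1.0-fold higher number from compound 1 to compound 3 (0.00 log units; within the scatter) and a 1.5-fold higher number from compound 2 to compound 3 (0.19 log units; within the scatter). Compound 4 `COc1ccc(/C=C\C(=O)O)c(OCc2cn(-c3ccccc3C#N)nn2)c1CC=C(C)C` is the next member; the change is cyano in place of iodo on an aromatic carbon. The three measured steps all swap the group on that same aromatic carbon: a 1.5-fold lower number from compound 1 to compound 2 (0.19 log units; within the scatter), a 1.0-fold higher number from compound 1 to compound 3 (0.00 log units; within the scatter) and a 1.5-fold higher number from compound 2 to compound 3 (0.19 log units; within the scatter), each within the scatter. On that basis no step beyond the scatter is expected for compound 4 in this assay, the estimated step being a 1.1-fold lower number from compound 3 to compound 4 (0.04 log units; within the scatter). The half-maximal inhibitory concentration of compound 4 is therefore estimated at 30000 nM, with a range from 15000 nM to 60000 nM.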

Compound 4, half-maximal inhibitory concentration: 10300 nM
Beside the measured number, compound 4's estimate is 2.9-fold (0.46 log units) above it, outside the stated range (below it).
By their numbers in this assay, from the lowest: compound 4; then compounds 2, 1 and 3 (each within the scatter of the next).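

In this assay the cyano group is the only one of the four on this aromatic carbon to move the number beyond the scatter, with a 3.2-fold lower number from compound 3 to compound 4 (0.50 log units; beyond the scatter) and a 2.1-fold lower number from compound 2 to compound 4 (0.31 log units; beyond the scatter) and a 3.2-fold lower number from compound 1 to compound 4 (0.50 log units; beyond the scatter) as its steps. Hydrogen, methoxy and iodo stay within the scatter of one another, so this position proved responsive to its substituent only with the 2-cyanophenyl group. No supporting measurement bears on the reason for this result. As far as these compounds go, whether an amide or a carboxylic acid on this same carbon would follow cyano or stay with the other three remains open.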